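Methoxy in Place of Chloro: What to Expect for Compound 3

The source may report more compounds than this note shows. Statements on the series, on what has been measured and on what is new or still open speak of the compounds shown alone.

Measured compounds:
compound 1 `O=C(Nc1nc2ccc(Cl)cc2s1)c1cn(-c2ccccc2)nc1-c1ccc(Cl)cc1`: 4360 nM
compound 2 `Cc1ccc2nc(NC(=O)c3cn(-c4ccccc4)nc3-c3ccc(Cl)cc3)sc2c1`: 18600 nM

In a functional assay on A549 cells (Homo sapiens) for cytotoxicity, read by MTT assay, with a stated time of 72 h (a lower number here means a stronger inhibitor, a higher number a weaker inhibitor), compound 1 gives 4360 nM and compound 2 gives 18600 nM. For the measured compounds named here, compound 2 thus stands at the higher of the two numbers, and its only neighbour is compound 1, reached through a 4.3-fold higher number from compound 1 to compound 2 (0.63 log units; beyond the scatter).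

Compound 3 `COc1ccc(-c2nn(-c3ccccc3)cc2C(=O)Nc2nc3ccc(C)cc3s2)cc1` has not been measured. It differs from compound 2 by methoxy in place of chloro on an aromatic carbon. Going by the values given here, the single measured step, a 4.3-fold higher number from compound 1 to compound 2 (0.63 log units; beyond the scatter), concerns a different part of the molecule, so no measured step bears directly on this change. With nothing in the data pointing to a change in either direction, the expectation is for no step beyond the scatter. The estimate for compound 3 in this assay is 20000 nM, expected to lie between 7000 nM and 60000 nM. This expectation amounts to a 1.1-fold higher number from compound 2 to compound 3 (0.03 log units; within the scatter).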

Compound 3, half-maximal inhibitory concentration: 27700 nM
The estimate for compound 3 lay 1.4-fold (0.14 log units) below the measured number; measured number inside the range.
By their numbers in this assay, from the lowest: compound 1; then compounds 2 and 3 (each within the scatter of the next).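

For the compounds shown here, compound 3 gives the first reading at this position, the para carbon of the aryl ring, which the earlier pair left untouched. Compounds 1 and 2 differ only in the other part of the molecule. In this assay, the change from 4-chlorophenyl to 4-methoxyphenyl gives a 1.5-fold higher number from compound 2 to compound 3 (0.17 log units; within the scatter), so replacing chloro with methoxy, which brings in a hydrogen-bond acceptor and one more heavy atom, produces no readable change on the methyl-bearing scaffold of compound 2. No supporting data are available to explain this result.

Going by these compounds, it remains open whether a group of a different kind at this carbon, such as an amine or a carboxylic acid, would move the number beyond the scatter. On these data alone, it is also open whether the same change would behave alike on the chloro-bearing scaffold of compound 1.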